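This account rests on a few compounds, and the source may have more. Where it says the series, first, only, none or still open, it means among the compounds named here.

Values measured in a functional assay on HeLa cells (Homo sapiens) for inhibition, read by MTT assay, with a stated time of 72 h (on this read-out higher numbers stand for weaker inhibition and lower numbers for stronger inhibition), are:
Compound 1 `COc1cc(NC(C)CCCNC(=O)Nc2cccc(Cl)c2)c2ncccc2c1` gives 17000 nM
Compound 2 `COc1cc(NC(C)CCCNC(=O)Nc2ccc(Br)cc2)c2ncccc2c1` gives 20000 nM
Compound 3 `COc1cc(NC(C)CCCNC(=O)NNC(=O)Nc2ccc(Br)cc2)c2ncccc2c1` gives 101000 nM

Compound 3 has the highest number of the three and is the weakest inhibitor among them. Compound 4 `COc1cc(NC(C)CCCNC(=O)NNC(=O)Nc2cccc(F)c2)c2ncccc2c1` carries 3-fluorophenyl in place of 4-bromophenyl on an amide-type nitrogen. The closest measured exchange, 4-bromophenyl in place of 3-chlorophenyl, gave a small change (a 1.2-fold higher number from compound 1 to compound 2 (0.07 log units; within the scatter)). The larger steps (a 5.9-fold higher number from compound 1 to compound 3 (0.77 log units; beyond the scatter); a 5.1-fold higher number from compound 2 to compound 3 (0.70 log units; beyond the scatter)) came with the entry of ((4-bromophenyl)carbamoyl)amino, a change that compound 4 does not undo. No shift beyond the scatter is therefore expected in this assay (a 1.3-fold lower number from compound 3 to compound 4 (0.10 log units; within the scatter)). For compound 4 the estimated value is 80000 nM (expected range 35000 nM to 180000 nM).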

Compound 4, half-maximal inhibitory concentration: > 250000 nM
Compound 4: a limit, no number (the forecaster's own chance of this, stated with the estimate: 10%); middle value at least 3.1-fold (0.49 log units) away from the limit.
By their numbers in this assay, from the lowest: compounds 1 and 2 (each within the scatter of the next); then compound 3. At a limit, above all of these: compound 4.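

In this assay compound 4 gives a limit, not a number: the limit of > 250000 nM in this assay, at which 1 of the 4 values shown sits. The aryl group on this amide-type nitrogen matters here: 3-fluorophenyl in place of 4-bromophenyl gives an at least 2.4-fold higher number from compound 3 to compound 4 (0.39 log units; beyond the scatter), whereas the earlier aryl exchange gave a 1.2-fold higher number from compound 1 to compound 2 (0.07 log units; within the scatter). Against the compounds lacking the extra carbamoylamino unit, the gap reaches an at least 12-fold higher number from compound 2 to compound 4 (1.09 log units; beyond the scatter) and an at least 14-fold higher number from compound 1 to compound 4 (1.16 log units; beyond the scatter). The compounds shown do not separate the halogen from its place on the ring, so what 4-fluorophenyl or 3-bromophenyl would give remains open. On these data alone, how far past its limit compound 4 lies also stays open.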